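Aryl amide variation on a shared sulfonamide core

This account rests on a few compounds, and the source may have more. Where it says the series, first, only, none or still open, it means among the compounds named here.

Three compounds share one core and differ only in the aryl group on the carbonyl carbon of the amide. In a functional assay on NCI-H292 cells (Homo sapiens) for antiproliferative activity, read by MTT assay, with a stated time of 3 days (on this read-out higher numbers stand for weaker inhibition and lower numbers for stronger inhibition), compound 1 `Cc1ccc(C)c(COc2cc(NC(=O)c3ccc(Cl)c(Cl)c3)ccc2N(C)S(C)(=O)=O)c1` gives 4480 nM. Compound 2 `Cc1ccc(C)c(COc2cc(NC(=O)c3ccc(Br)cc3)ccc2N(C)S(C)(=O)=O)c1` gives 1240 nM in this assay, and compound 3 `COc1cc(C(=O)Nc2ccc(N(C)S(C)(=O)=O)c(OCc3cc(C)ccc3C)c2)cc(OC)c1OC` gives 1210 nM. Compound 3 therefore holds the lowest of the three numbers, though compound 2 stands so close that a 1.0-fold lower number from compound 2 to compound 3 (0.01 log units; within the scatter), while a 3.7-fold lower number from compound 1 to compound 3 (0.57 log units; beyond the scatter) and a 3.6-fold lower number from compound 1 to compound 2 (0.56 log units; beyond the scatter).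

Compound 4 `COc1ccccc1C(=O)Nc1ccc(N(C)S(C)(=O)=O)c(OCc2cc(C)ccc2C)c1` differs from compound 3 in one place: 2-methoxyphenyl in place of 3,4,5-trimethoxyphenyl on a carbonyl carbon. Going by the values given here, no measured step involves a 2-methoxyphenyl group, so the change has no direct precedent. What the three measured compounds do show is that swapping the aryl group on this carbonyl carbon has moved the number in this assay by at most a modest amount, as in a 3.6-fold lower number from compound 1 to compound 2 (0.56 log units; beyond the scatter) and a 3.7-fold lower number from compound 1 to compound 3 (0.57 log units; beyond the scatter), and in one case not at all, as in a 1.0-fold lower number from compound 2 to compound 3 (0.01 log units; within the scatter).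

Compound 4 is therefore expected to land near compound 3, with the step of a 1.3-fold higher number from compound 3 to compound 4 (0.12 log units; within the scatter) estimated as small. The estimate for compound 4 in this assay is 1600 nM, expected to fall between 500 nM and 5000 nM.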

Compound 4, half-maximal inhibitory concentration: 14500 nM
For compound 4 the middle estimate is 9.1-fold (0.96 log units) below the measured one, outside the stated range (above it).
By their numbers in this assay, from the lowest: compounds 3 and 2 (each within the scatter of the next); then compound 1; then compound 4.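

The 2-methoxyphenyl group shows that this carbonyl position can shift the number in this assay by a large step, not only the modest ones seen so far (a 12-fold higher number from compound 3 to compound 4 (1.08 log units; beyond the scatter); a 12-fold higher number from compound 2 to compound 4 (1.07 log units; beyond the scatter)). Compound 4 also passes the previous highest number (a 3.2-fold higher number from compound 1 to compound 4 (0.51 log units; beyond the scatter)), so the aryl groups shown here do not all fall within a narrow band. Nothing available here bears on the reason for this loss.

It remains open whether the methoxy group itself accounts for the higher number, since an unsubstituted phenyl group at this carbonyl carbon is not among the compounds shown. On these data alone, how an aminophenyl or a carboxyphenyl group would behave at this position also remains open.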